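The compounds below may be only part of what the source reports. "The series", "measured", "known", "first", "only" and "open" are said of these compounds alone.

Working notes on the series in a toxicity assay on HepG2 cells (Homo sapiens) for inhibition, read by CellTiter-Glo, with a stated time of 48 h; a higher number here means a weaker inhibitor, a lower number a stronger inhibitor.

The compounds share one core. Compound 1 is `CSc1ccc2nc(C)cc(OCC(=O)Nc3cc(C)cc(C)c3)c2c1`, compound 2 is `COc1ccc2nc(C)cc(OCCNc3cc(C)cc(C)c3)c2c1`, compound 3 is `COc1ccc2nc(C)cc(OCC(=O)Nc3cc(C)ccc3C)c2c1` and compound 4, not yet measured, is `COc1ccc2nc(C)cc(OCC(=O)Nc3ccc(Cl)cc3Cl)c2c1`.

In this assay compound 2 gives 31600 nM. For compound 1 this assay reports only a limit, > 100000 nM. For compound 3 this assay likewise reports only a limit, > 100000 nM, so compound 3 stands at the edge of what this assay resolves. For the measured compounds named here, no pair of the measured compounds differs in a single place, so no measured step can be read from these three; what they show is the limit of > 100000 nM in this assay, at which 2 of the 3 values shown sit, with the numeric value of compound 2 the only one inside the window.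

The change from compound 3 to compound 4 is 2,4-dichlorophenyl in place of 2,5-dimethylphenyl on an amide-type nitrogen whose other neighbour is a carbonyl carbon. With compound 3 at a limit, the step of a number no higher from compound 3 to compound 4 (the limit leaves the size open) is expected to be no more than the scatter, and a second limit is the likeliest outcome. Compound 4 is expected to give about 100000 nM, within 30000 nM to 300000 nM.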

Compound 4, half-maximal inhibitory concentration: > 100000 nM
Compound 4 ended at the assay's limit; the forecaster's own chance of this, stated with the estimate: 60%; the middle value sits exactly at the limit.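

For the compounds shown here, compound 3 and compound 4 both stand at a limit in this assay and give no number, so no step between them can be read. The series now rests mostly on such limits: the limit of > 100000 nM in this assay, at which 3 of the 4 values shown sit. The compounds shown leave open whether 2,4-dichlorophenyl in place of 2,5-dimethylphenyl on an amide-type nitrogen has any effect in this assay.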